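This account rests on a few compounds, and the source may have more. Where it says the series, first, only, none or still open, it means among the compounds named here.

Measured so far in an assay for inhibition of Thromboxane-A synthase (Homo sapiens), using microsomes; on this read-out lower numbers stand for stronger inhibition and higher numbers for weaker inhibition:
- compound 1 `O=C(O)CC/C=C\CC1COC(c2cccs2)OC1c1cccnc1` gives 71 nM
- compound 2 `CC(C)(Oc1ccc(F)cc1)C1OCC(C/C=C\CCC(=O)O)C(c2cccnc2)O1` gives 51 nM

Compound 2 holds the lowest of the two numbers in this assay, but its nearest neighbour, compound 1, differs from it by less than the usual scatter, so the two cannot be told apart on these data. Within the data shown here, no step between compounds that differ in one place has been recorded, so there is no measured precedent for the change that follows.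

Compound 3 `CC(C)(Oc1ccccc1O)C1OCC(C/C=C\CCC(=O)O)C(c2cccnc2)O1` is the next compound to be measured. It differs from compound 2 in one place: 2-hydroxyphenyl in place of 4-fluorophenyl on an oxygen on a saturated carbon. In both compounds the remainder of the structure, the shared core with its pyridinyl group and the acid-bearing chain, is kept unchanged.

With no shown step to lean on, the expectation for the change from compound 2 to compound 3 in this assay is a step of about a 1.1-fold higher number from compound 2 to compound 3 (0.03 log units; within the scatter), that is, no move beyond the scatter. Compound 3 is therefore estimated at 55 nM, with a range from 18 nM to 170 nM.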

Compound 3, half-maximal inhibitory concentration: 32 nM
Compound 3: middle estimate off by 1.7-fold (0.24 log units), on the high side, within the range that was stated.
By their numbers in this assay, from the lowest: compounds 3, 2 and 1 (each within the scatter of the next, the first and the last beyond it).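

Working notes on the aryl group of this series, read in this assay: the swap of 4-fluorophenyl for 2-hydroxyphenyl on an oxygen on a saturated carbon gives a 1.6-fold lower number from compound 2 to compound 3 (0.20 log units; within the scatter) and so leaves compound 2 and compound 3 indistinguishable. Among these compounds, this is the first one-place step, and it shows that this position accepts a group carrying 1 hydrogen-bond donor and 1 hydrogen-bond acceptor in place of one carrying neither, with the heavy-atom count and the aromatic ring unchanged, and without a move beyond the scatter. Nothing at hand accounts for how the two compounds read, so the result stands as an observation only.

The step changes both the substituent and its place on the ring at once, so the contribution of each cannot be separated without compounds bearing 4-hydroxyphenyl, 2-fluorophenyl or unsubstituted phenyl at this position. Also open, from the compounds shown here alone, is how far the position's tolerance extends, for example to 2-methoxyphenyl, to a 2-aminophenyl group, or to a 2-carboxyphenyl group, which would test whether the hydroxyl can be replaced by other groups.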